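Propargyl ester step on the methylamino-phenyl core

A few compounds are considered here, and "the series" means these few. Any claim that something is new, unique, unknown or untested is made for them only; others in the source may bear on it.

Compound 1 `CCOC(=O)CC1C(C(=O)OCC)=C(N)Oc2ccc(-c3cc(OC)cc(OC)c3)cc21` and compound 2 `C#CCOC(=O)CC1C(C(=O)OCC)=C(N)Oc2ccc(-c3cc(OC)cc(OC)c3)cc21` share one core and differ in a single place, (ethynyl in place of methyl on a saturated chain carbon bound to an oxygen next to a carbonyl group). Among the measured compounds shown here, in a functional assay on HL-60 cells (Homo sapiens) for cytotoxicity, read by CellTiter-Blue, with a stated time of 48 h (on this read-out higher numbers stand for weaker inhibition and lower numbers for stronger inhibition), compound 1 gives 10700 nM, and compound 2 gives 4700 nM; the step of a 2.3-fold lower number from compound 1 to compound 2 (0.36 log units; beyond the scatter) is the only beyond-scatter step among the three measured compounds.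

Compound 3 `CCOC(=O)CC1C(C(=O)OCC)=C(N)Oc2ccc(-c3cccc(NC)c3)cc21` carries a second core, which differs from that of compound 1 as 3-(methylamino)phenyl in place of 3,5-dimethoxyphenyl on an aromatic carbon. In this assay compound 3 gives 7450 nM; the step of a 1.4-fold lower number from compound 1 to compound 3 (0.16 log units; within the scatter) says nothing about order between these two compounds. Compound 3 and compound 2 are also within the usual scatter of each other.

Compound 4 `C#CCOC(=O)CC1C(C(=O)OCC)=C(N)Oc2ccc(-c3cccc(NC)c3)cc21` is not yet measured. It stands to compound 3 as compound 2 stands to compound 1: the change is ethynyl in place of methyl on a saturated chain carbon bound to an oxygen next to a carbonyl group, and the two place descriptions read the same word for word, so this is taken as the same change, now made on the core of compound 3. For the measured compounds named here, only one instance of the change has been measured, so how far it carries over to the second core is unknown.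

The expectation for compound 4 rests on the measured step of a 2.3-fold lower number from compound 1 to compound 2 (0.36 log units; beyond the scatter) applied to compound 3 at 7450 nM. The step from compound 3 to compound 4 in this assay is expected to be a 2.2-fold lower number from compound 3 to compound 4 (0.34 log units; beyond the scatter), of about the size seen before. Compound 4 is estimated at 3400 nM in this assay, with a range from 1700 nM to 7500 nM to allow for the change not transferring fully.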

Compound 4, half-maximal inhibitory concentration: 7130 nM
For compound 4 the middle estimate is 2.1-fold (0.32 log units) below the measured one; measured number inside the range.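

In this assay, among the compounds shown here, the ethyl to propargyl change on the core of compound 3 gives a 1.0-fold lower number from compound 3 to compound 4 (0.02 log units; within the scatter), so on this core the change produces no step that can be read, unlike the one seen on the core of compound 1. Even so, the two steps cannot be called different, and the data show neither that the change is tied to the core of compound 1 nor that it carries over at its earlier size: the same change on two cores in this assay, a 2.3-fold lower number (0.36 log units; beyond the scatter) from compound 1 to compound 2 and a 1.0-fold lower number (0.02 log units; within the scatter) from compound 3 to compound 4, 2.2-fold (0.34 log units) apart, within the scatter of two such steps. The exchange of 3,5-dimethoxyphenyl for 3-(methylamino)phenyl, now read on the propargyl esters as a 1.5-fold higher number from compound 2 to compound 4 (0.18 log units; within the scatter), gives the same picture, with no dependence of one change on the other established from this single square of compounds: the same change on two cores in this assay, a 1.4-fold lower number (0.16 log units; within the scatter) from compound 1 to compound 3 and a 1.5-fold higher number (0.18 log units; within the scatter) from compound 2 to compound 4, 2.2-fold (0.34 log units) apart, within the scatter of two such steps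

The compounds shown leave open whether a propyl or allyl ester would behave like the propargyl ester on either core, which would separate the effect of chain length from that of the triple bond. Also open, on these data alone, is whether a carboxylic acid or an amide in place of the ester, or a further aryl group such as 3-aminophenyl, would give steps large enough to read in this assay.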